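Methylene insertion on the ring nitrogen of compound 2

This account rests on a few compounds, and the source may have more. Where it says the series, first, only, none or still open, it means among the compounds named here.

Within the data shown here, compound 2 `CO[C@H]1CC[C@@H](N2CC(=O)Nc3ncc(-c4ccc(C(C)(C)O)nc4)nc32)CC1` gives 70% in a functional assay on the whole organism (PC-3 cells) for inhibition, with Mus musculus as the target, in a xenograft, with a stated time of 24 h, at a dose of 100 mg/kg by the oral route (a lower number here means less inhibition, a higher number more inhibition at the dose given (going by the name of the read-out)), the higher of the two numbers so far; compound 1 `CC(C)(O)c1ccc(-c2cnc3c(n2)N(CCC2CCOCC2)C(=O)CN3)cn1` gives 59% in this assay, and the gap between the two values lies beyond the scatter. Compound 3 `CO[C@H]1CC[C@H](CN2CC(=O)Nc3ncc(-c4ccc(C(C)(C)O)nc4)nc32)CC1` carries (4-methoxycyclohexyl)methyl in place of 4-methoxycyclohexyl on a nitrogen on an aromatic ring in a ring. Among the measured compounds shown here, no measured pair spans this change on its own, so the size of the step is open; a modest shift, in either direction and not clearly beyond the scatter, is expected. Compound 3 is estimated at 62% in this assay, within 42% to 80%, which means an expected step of a number 8 percentage points lower from compound 2 to compound 3 (within the scatter).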

Compound 3, a percentage reported as inhibition, in the whole organism at one dose (the size of the read-out at that dose, not a potency): 0%
Estimate against measurement, compound 3: 62 percentage points above, and the stated range ends above it.
By their numbers in this assay, from the lowest: compound 3; then compound 1; then compound 2.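

Among these compounds, the single pair gives the first direct reading at this nitrogen: (4-methoxycyclohexyl)methyl in place of 4-methoxycyclohexyl gives a large step in this assay, a number 70 percentage points lower from compound 2 to compound 3 (beyond the scatter). The substituents differ by one carbon, yet compound 3 reads 0%, so this position is far less forgiving of this change than the two earlier values could show. Nothing available here accounts for the loss. A single-dose whole-organism read-out cannot separate potency from exposure. Also open, going by these compounds, is how a 4-hydroxycyclohexyl group or a longer chain, such as 2-(4-methoxycyclohexyl)ethyl, would read on this nitrogen.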